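The compounds below may be only part of what the source reports. "The series", "measured", "known", "first", "only" and "open" are said of these compounds alone.

Compound 1 `Cc1c2c(n3c1CCN(C(=O)[C@H](C)N)CC[C@H](C)Nc1cc-3ccc1C(N)=O)CC(C)(C)CC2=O`, compound 2 `Cc1c2c(n3c1CCCNC[C@H](C)Nc1cc-3ccc1C(N)=O)CC(C)(C)CC2=O` and compound 3 `COCCN1CC[C@H](C)Nc2cc(ccc2C(N)=O)-n2c(c(C)c3c2CC(C)(C)CC3=O)CC1=O` have all been tested in an in vitro ADME assay on microsomes from liver (Rattus norvegicus) for metabolic stability; a higher number here means that the compound lasts longer, a lower number that the compound disappears faster. Compound 2 gives > 0.5 h, which is a limit of the assay and not a number. Compound 1 also gives only a limit, > 0.5 h. Compound 3 likewise gives a limit, > 0.5 h. The whole record is therefore (the limit of > 0.5 h in this assay, at which 3 of the 3 values shown sit), and compound 2 cannot be ranked against the other two.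

Compound 4 `CC(=O)N1CCCc2c(C)c3c(n2-c2ccc(C(N)=O)c(c2)N[C@@H](C)C1)CC(C)(C)CC3=O` differs from compound 2 by acetyl in place of hydrogen on an amine nitrogen in a ring, with acetyl in place of hydrogen on an amine nitrogen in a ring. Among the compounds with values here, no measured pair shows this change, so no step beyond the usual scatter, in either direction, is expected: the estimated step is a step that the limit leaves unreadable from compound 2 to compound 4. For compound 4 the estimated half-life is 1 h, with an expected range of 0.4 h to 3 h.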

Compound 4, half-life in the Rattus norvegicus assay: 0.183 h
The estimate for compound 4 lay 5.5-fold (0.74 log units) above the measured number, outside the stated range (below it).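

Compound 4 gives the first readable result at this ring nitrogen: in the Rattus norvegicus assay, acetyl in place of hydrogen brings an at least 2.7-fold lower number from compound 2 to compound 4 (0.43 log units; beyond the scatter). The earlier compounds could show no such change, and compound 2 itself rests on a limit: the limit of > 0.5 h in the Rattus norvegicus assay, at which 3 of the 4 values shown sit.

In a physicochemical assay for solubility (on this read-out higher numbers stand for higher solubility and lower numbers for lower solubility), compound 2 gives > 100 ug/mL, which is a limit of the assay and not a number. In the physicochemical assay, compound 4 gives 69 ug/mL. In the physicochemical assay, the same change gives an at least 1.4-fold lower number from compound 2 to compound 4 (0.16 log units; that floor lies within the scatter), whose floor stays within the usual scatter, so no shift in solubility can be claimed: the limit of > 100 ug/mL in the physicochemical assay, at which 1 of the 2 values shown sits.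

This single pair leaves open whether the shorter half-life belongs to acetyl alone or to any group placed on this nitrogen. A plain methyl or a methanesulfonyl group there could help to separate the two.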